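A few compounds are considered here, and "the series" means these few. Any claim that something is new, unique, unknown or untested is made for them only; others in the source may bear on it.

Of the compounds shown here, three built on a shared core have been measured in an assay on HEK293 cells for agonist activity at Toll-like receptor 8 (Homo sapiens), read by a luciferase reporter, with a stated time of 6 h; a higher number here means that more compound is needed for the effect, a lower number that less compound is needed. Compound 1 `CCCCNc1nc(N)nc2c1CCN(S(C)(=O)=O)C2` gives 0.8 uM in this assay. Compound 2 `CCCCNc1nc(N)nc2c1CN(Cc1ccc(C(F)(F)F)cc1)CC2` gives 0.23 uM in this assay. Compound 3 `CCCCNc1nc(N)nc2c1CN(Cc1ccccn1)CC2` gives 0.07 uM in this assay, the lowest of the three numbers; compound 2 lies nearest to it and compound 1 furthest, and both gaps are beyond the usual scatter of repeated measurements.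

Compound 4 `CCCCNc1nc(N)nc2c1CN(C(=O)c1scnc1C)CC2` has not yet been measured in this assay. It differs from compound 3 in one place: (4-methyl-1,3-thiazol-5-yl)carbonyl in place of (pyridin-2-yl)methyl on an amine nitrogen in a ring. Within the data shown here, no measured pair shows this exact change, so the expectation can rest only on the spread of the three values, in which compound 3 holds the lowest number. Since the change removes the group that goes with that lowest number, compound 4 is expected to need more compound than compound 3, a moderate step of a 5.7-fold higher number from compound 3 to compound 4 (0.76 log units; beyond the scatter) in this assay that goes beyond the scatter. Compound 4 is therefore estimated at 0.4 uM, within a range from 0.1 uM to 1.5 uM.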

Compound 4, minimum effective concentration: 5.6 uM
Estimate against measurement, compound 4: 14-fold (1.15 log units) below, outside the stated range (above it).
By their numbers in this assay, from the lowest: compound 3; then compound 2; then compound 1; then compound 4.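

In this assay, putting (4-methyl-1,3-thiazol-5-yl)carbonyl in place of (pyridin-2-yl)methyl on the amine nitrogen in a ring gives an 80-fold higher number from compound 3 to compound 4 (1.90 log units; beyond the scatter) and is a large step, so this position is far from indifferent to the group it carries. The swap alters two things at once: a six-membered aromatic ring with 1 hetero atom gives way to a five-membered one with 2 hetero atoms, and the link to the nitrogen becomes a carbonyl. Nothing available explains why the number rises so far.

Which of those two alterations accounts for the step remains open. (Pyridin-2-yl)carbonyl or (4-methyl-1,3-thiazol-5-yl)methyl on the same nitrogen would each change only one of them and so could separate the two.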